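Dropping a Methoxy Group: From Compound 3 to Compound 4

The compounds below may be only part of what the source reports. "The series", "measured", "known", "first", "only" and "open" are said of these compounds alone.

Three compounds sharing one core were tested in a functional assay on cells (Erythrocyte, Rattus norvegicus) for inhibition, read by hemolysis, with a stated time of 1 h; a lower number here means a stronger inhibitor, a higher number a weaker inhibitor. Compound 1 `COc1cc(OC)c(OC)cc1/C=C/C(=O)c1ccc(O)cc1O` gives 2.37 ug/mL, compound 2 `COc1cc(OC)c(OC)cc1/C=C/C(=O)c1cccc(C(F)(F)F)c1` gives 2.3 ug/mL, and compound 3 `COc1ccc(C(=O)/C=C/c2cc(OC)c(OC)cc2OC)cc1` gives 2.18 ug/mL. Compound 3 has the lowest of the three numbers, but all three lie within the scatter of one another, so no order can be read from them. For the measured compounds named here, the single measured step, a 1.1-fold lower number from compound 1 to compound 3 (0.04 log units; within the scatter), changed nothing beyond the scatter. Compound 4 `COc1cc(OC)c(OC)cc1/C=C/C(=O)c1ccccc1` differs from compound 3 by hydrogen in place of methoxy on an aromatic carbon. Going by the values given here, no measured step tests this change directly, and the one known step left the number unchanged. Compound 4 is therefore expected to give a number close to that of compound 3. The estimate for compound 4 is 2.4 ug/mL, with a range from 1.2 ug/mL to 4.8 ug/mL, meaning an expected step of a 1.1-fold higher number from compound 3 to compound 4 (0.04 log units; within the scatter).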

Compound 4, half-maximal inhibitory concentration: 2.23 ug/mL
The estimate for compound 4 lay 1.1-fold (0.03 log units) above the measured number; measured number inside the range.
By their numbers in this assay, from the lowest: compounds 3, 4, 2 and 1 (each within the scatter of the next).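

Taking the methoxy group off leaves a plain phenyl, and this gives a 1.0-fold higher number from compound 3 to compound 4 (0.01 log units; within the scatter) in this assay. The plain phenyl also stands within the scatter of the substituted rings, with a 1.0-fold lower number from compound 2 to compound 4 (0.01 log units; within the scatter) and a 1.1-fold lower number from compound 1 to compound 4 (0.03 log units; within the scatter), so methoxy, trifluoromethyl and the two hydroxyl groups each show no measurable difference from having no such group at all. No available evidence explains this flat result. On these data alone, whether an amine or a carboxylic acid on this ring would shift the number stays open, as does the effect of changes elsewhere in the shared core.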